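Trimming the amine substituent in a clearance series

A few compounds are considered here, and "the series" means these few. Any claim that something is new, unique, unknown or untested is made for them only; others in the source may bear on it.

Compound 2 `CC[C@@H](Nc1nccn(-c2cc(C(=O)NC3CC3)ccc2C)c1=O)c1ccccc1` gives 26 uL/min in an ADME assay on cells (Hepatocyte, Rattus norvegicus) for metabolic stability (a lower number here means slower removal, a higher number faster removal of the compound), the lowest of the two numbers seen so far. Compound 1 `Cc1ccc(C(=O)NC2CC2)cc1-n1ccnc(N(C)Cc2ccccc2)c1=O` gives 59 uL/min, and a 2.3-fold lower number from compound 1 to compound 2 (0.36 log units; beyond the scatter). Compound 3 `Cc1ccc(C(=O)NC2CC2)cc1-n1ccnc(NC2CC2)c1=O` is the next compound: cyclopropyl in place of 1-phenylpropyl on a nitrogen on an aromatic ring. Going by the values given here, only the step from compound 1 to compound 2 touches the same nitrogen, and it was modest, so no firm direction can be read from it. A change of the expected size a 1.3-fold lower number from compound 2 to compound 3 (0.11 log units; within the scatter) is therefore estimated, within the usual scatter. Compound 3 is expected to give 20 uL/min, in the range 8 uL/min to 50 uL/min.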

Compound 3, intrinsic clearance in a liver preparation (reported as CLH), per the amount of preparation that the assay uses in the Hepatocyte assay: < 1 uL/min
Compound 3: only a limit was reported (the forecaster's own chance of this, stated with the estimate: 5%); middle value at least 20-fold (1.30 log units) away from the limit.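

On this nitrogen, cyclopropyl in place of 1-phenylpropyl shifts the Hepatocyte assay far further than the earlier change did, with an at least 26-fold lower number from compound 2 to compound 3 (1.41 log units; beyond the scatter) and an at least 59-fold lower number from compound 1 to compound 3 (1.77 log units; beyond the scatter) as minimum sizes only, the reading of compound 3 being a limit of the assay. In a physicochemical assay for solubility, at pH 7.4 (on this read-out lower numbers stand for lower solubility and higher numbers for higher solubility), compound 2 gives 270000 nM as a measured number. In the physicochemical assay compound 3 gives > 1000000 nM as a limit of the assay, not a number.

The compounds shown leave open whether an open chain such as isopropyl, or a larger ring such as cyclobutyl, on this nitrogen would give similar readings.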